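The source may report more compounds than this note shows. Statements on the series, on what has been measured and on what is new or still open speak of the compounds shown alone.

The study opens with two measured compounds. Compound 1, `O=C(/C=C(O)/C=C/c1ccccc1)c1ccccc1O`, gives 1160 nM in an in vitro assay on cells for inhibition of Amine oxidase [flavin-containing] B (Homo sapiens), read by Amplex Red, with a stated time of 15 min (on this read-out lower numbers stand for stronger inhibition and higher numbers for weaker inhibition), while compound 2, `O=C(/C=C/C=C/c1ccc([N+](=O)[O-])cc1)c1ccccc1O`, gives 160 nM in this assay. Compound 2 thus holds the lowest of the two numbers, with compound 1 the nearest at a gap beyond the usual scatter. The account now turns to compound 3, `O=C(/C=C/C=C/c1ccccc1)c1ccccc1O`, which has not yet been measured. Compound 3 differs from compound 2 in one place: hydrogen in place of nitro on an aromatic carbon. For the measured compounds named here, no step between measured compounds involves this change, so nothing yet shows what a hydrogen in place of nitro on an aromatic carbon does here. Compound 3 is expected to give a somewhat higher number in this assay than compound 2, with an estimated step of a 3.1-fold higher number from compound 2 to compound 3 (0.49 log units; beyond the scatter) of moderate size. For compound 3 the expected value in this assay is 500 nM, within a range of 150 nM to 1700 nM.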

Compound 3, half-maximal inhibitory concentration: 106 nM
For compound 3 the middle estimate is 4.7-fold (0.67 log units) above the measured one; the measured number lies below the stated range.
By their numbers in this assay, from the lowest: compounds 3 and 2 (each within the scatter of the next); then compound 1.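

At this aromatic carbon, para to a large group, hydrogen in place of nitro gives a 1.5-fold lower number from compound 2 to compound 3 (0.18 log units; within the scatter) in this assay and so stays within the scatter, which shows that the nitro group is not needed for a number of this size on this core. For the compounds shown here, on the chain, hydrogen in place of hydroxy on a double-bonded chain carbon bound to two double-bonded chain carbons gives an 11-fold lower number from compound 1 to compound 3 (1.04 log units; beyond the scatter) and is thus the only one of the two changes to go beyond the scatter. Nothing measured here bears on why either change has the size it has.

The compounds shown leave open whether a methoxy group or an amine on that aromatic carbon would also stay within the scatter of compound 3. They also leave open what a methyl group or a fluorine atom on that chain carbon would do.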